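The compounds below may be only part of what the source reports. "The series", "measured", "known", "first", "only" and "open" are said of these compounds alone.

Measured compounds:
compound 1 `O=C1c2ccccc2N(Cc2ccccc2)S(=O)(=O)N1Cc1ccccc1` gives 66000 nM in a functional assay on MRC5 cells (Homo sapiens); on this read-out higher numbers stand for lower toxicity in this test and lower numbers for higher toxicity in this test
compound 2 `O=S1(=O)N=C(OCc2ccc(Cl)c(Cl)c2)c2ccccc2N1Cc1ccc(Cl)c(Cl)c1` gives 48000 nM in this assay
compound 3 `O=C1c2ccccc2N(Cc2ccc(Cl)c(Cl)c2)S(=O)(=O)N1Cc1ccccc1` gives 56000 nM in this assay

These three numbers lie within the usual scatter of one another, so none of the three can be called less or more toxic than another. Compound 1 and compound 3 share a core and differ in one place: phenyl in place of 3,4-dichlorophenyl on a saturated chain carbon bound to a sulfonamide nitrogen in a ring. That change made a 1.2-fold higher number from compound 3 to compound 1 (0.07 log units; within the scatter). Compound 4 `O=S1(=O)N=C(OCc2ccccc2)c2ccccc2N1Cc1ccc(Cl)c(Cl)c1` has not yet been measured. It differs from compound 2 in one place: phenyl in place of 3,4-dichlorophenyl on a saturated chain carbon bound to an oxygen on an unsaturated carbon. The difference between the cores of compound 2 and compound 3 is not broken down here. The two replacements are the same kind of change, but the place differs: in compound 3 it is on a saturated chain carbon bound to a sulfonamide nitrogen in a ring, in compound 2 on a saturated chain carbon bound to an oxygen on an unsaturated carbon. Because the earlier step was a 1.2-fold higher number from compound 3 to compound 1 (0.07 log units; within the scatter), a step of about the same small size is expected here, a 1.1-fold higher number from compound 2 to compound 4 (0.06 log units; within the scatter). Compound 4 is therefore estimated at 55000 nM, with a likely range from 30000 nM to 100000 nM.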

Compound 4, half-maximal cytotoxic concentration: 56000 nM
Beside the measured number, compound 4's estimate is 1.0-fold (0.01 log units) below it, and the stated range covers the measured number.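

Replacing 3,4-dichlorophenyl with phenyl, on a saturated chain carbon bound to an oxygen on an unsaturated carbon, gave a 1.2-fold higher number from compound 2 to compound 4 (0.07 log units; within the scatter) in this assay. The same kind of change on the other core, at a different place, gave a step of matching size: the same change on two cores in this assay, a 1.2-fold higher number (0.07 log units; within the scatter) from compound 3 to compound 1 and a 1.2-fold higher number (0.07 log units; within the scatter) from compound 2 to compound 4, 1.0-fold (0.00 log units) apart, within the scatter of two such steps This shows that, in these two pairs, the change carries from one core to the other in the limited sense that it leaves the number within the scatter both times, but it does not show that the change has any real effect on toxicity in this test, or that a third core would behave the same way.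

The compounds shown hold only phenyl and 3,4-dichlorophenyl on these chains, so what an amine, a carboxylic acid or a longer chain would do there remains open. Also open, on these data alone, is whether any change at these places can move the number beyond the scatter.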